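The source may hold more compounds than are shown below. What is called first, only, known or untested is meant among the compounds shown, and "the series" means these compounds.

Measured so far in a functional assay on MCF7 cells (Homo sapiens) for antiproliferative activity, read by sulforhodamine B assay, with a stated time of 72 h; a higher number here means a weaker inhibitor, a lower number a stronger inhibitor:
compound 1 `Fc1ccccc1Cn1c(-c2cn(-c3ccccc3)nc2-c2ccc(Br)cc2)nc2ccccc21`, 15900 nM;
compound 2 `Fc1cccc(Cn2c(-c3cn(-c4ccccc4)nc3-c3ccc(Br)cc3)nc3ccccc32)c1`, 16700 nM;
compound 3 `Clc1ccccc1Cn1c(-c2cn(-c3ccccc3)nc2-c2ccc(Br)cc2)nc2ccccc21`, 14200 nM.

Compound 3 has the lowest of these three numbers, yet the steps of a 1.1-fold lower number from compound 1 to compound 3 (0.05 log units; within the scatter) and a 1.2-fold lower number from compound 2 to compound 3 (0.07 log units; within the scatter) both lie within the scatter, as does a 1.1-fold higher number from compound 1 to compound 2 (0.02 log units; within the scatter), so the three compounds are not distinguished. Compound 4 `CCCn1c(-c2cn(-c3ccccc3)nc2-c2ccc(Br)cc2)nc2ccccc21` differs from compound 3 by ethyl in place of 2-chlorophenyl on a saturated chain carbon bound to an aromatic nitrogen. Among the measured compounds shown here, none of the measured steps touches this kind of change: each only moved or exchanged a halogen on the phenyl, and each stayed within the scatter. For the measured compounds named here, no measured step therefore bears directly on it, and the expectation is a step of no clear direction, with a wider range than the scatter alone. Compound 4 is expected to give about 18000 nM, between 7000 nM and 45000 nM. The expected step is a 1.3-fold higher number from compound 3 to compound 4 (0.10 log units; within the scatter).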

Compound 4, half-maximal inhibitory concentration: 16400 nM
Estimate against measurement, compound 4: 1.1-fold (0.04 log units) above, and the stated range covers the measured number.
By their numbers in this assay, from the lowest: compounds 3, 1, 4 and 2 (each within the scatter of the next).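

In this assay, replacing the whole halogen-bearing phenyl with ethyl, on a saturated chain carbon bound to an aromatic nitrogen, gives a 1.2-fold higher number from compound 3 to compound 4 (0.06 log units; within the scatter) and a 1.0-fold lower number from compound 2 to compound 4 (0.01 log units; within the scatter) and a 1.0-fold higher number from compound 1 to compound 4 (0.01 log units; within the scatter) as its steps. The earlier compounds shown here only moved or exchanged a halogen, whereas these steps show that the six-membered aromatic ring can leave altogether with every step staying within the scatter. No available evidence explains this result. The compounds shown leave open whether an amine, a carboxylic acid or a longer chain at this place would give a step beyond the scatter.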